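Ether-linked benzoic acid series: notes toward compound 4

The source may report more compounds than this note shows. Statements on the series, on what has been measured and on what is new or still open speak of the compounds shown alone.

Measured so far:
compound 1 `Cc1c(OCCCCOc2ccc(C(=O)O)cc2F)ccc(C(=O)CC2CCCC2)c1O` — 83.8%
compound 2 `COC(=O)c1ccc(OCCCCOc2ccc(C(=O)CC3CCCC3)c(C)c2C)cc1` — 14.1%
compound 3 `Cc1c(OCCCCOc2ccc(C(=O)O)cc2F)ccc(C(=O)CC(C)C)c1O` — 85%

In an assay on HEK293 cells for positive allosteric modulation of metabotropic glutamate receptor 2 (Rattus norvegicus), read by thallium flux, with a stated time of 2.5 min (a higher number here means a larger maximal response, a lower number a smaller maximal response), compound 3 gives the highest of the three numbers. For the measured compounds named here, compound 1 stands nearest, and the single step of a number 1.2 percentage points higher from compound 1 to compound 3 (within the scatter) is within the scatter, so no order between compound 1 and compound 3 can be claimed. Compound 2 gives the lowest number, but it differs from compound 3 in more than one place, so only the two values themselves can be compared.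

Compound 4 `Cc1c(OCCCCOc2ccc(C(=O)O)c(Cl)c2)ccc(C(=O)CC(C)C)c1O` is the next step from compound 3: 4-carboxy-3-chlorophenyl in place of 4-carboxy-2-fluorophenyl on an oxygen on a saturated carbon. Going by the values given here, no measured step touches this part of the molecule; the one step measured, a number 1.2 percentage points higher from compound 1 to compound 3 (within the scatter), concerns the saturated chain carbon bound to the carbonyl carbon and was within the scatter. Compound 2 offers no single-step guidance for the aryl end. The step to compound 4 is therefore expected to be small, a number 9 percentage points lower from compound 3 to compound 4 (within the scatter), with a broad range. Compound 4 is estimated at 76%, between 45% and 95%.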

Compound 4, largest response reached (reported as percent of maximum), in percent of the reference or control that the assay uses: 80.5%
Compound 4: middle estimate off by 4.5 percentage points, on the low side; low and high end bracket the measured number.
By their numbers in this assay, from the lowest: compound 2; then compounds 4, 1 and 3 (each within the scatter of the next).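

In this assay, for the compounds shown here, the first measured step at the aryl end, 4-carboxy-3-chlorophenyl in place of 4-carboxy-2-fluorophenyl on an oxygen on a saturated carbon, gives a number 4.5 percentage points lower from compound 3 to compound 4 (within the scatter), so the high response of compound 3 survives this exchange. The step changes the halogen and its place on the ring together, so the two changes cannot be read apart. No measured evidence on the origin of this result is at hand.

Open, from the compounds shown here alone, is how a 4-carboxyphenyl group with no halogen would read, and whether a tetrazole could stand in for the carboxylic acid. Compound 2, which carries a methyl ester, differs from compound 3 in more than one place, so the contribution of the carboxylic acid itself remains unresolved.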